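The source may hold more compounds than are shown below. What is called first, only, known or untested is meant among the compounds shown, and "the series" means these compounds.

Compound 1 `CC(=O)OCCc1c(C)nc(Cl)nc1Cl` gives > 100000 nM in a functional assay on MOLT-4 cells (Homo sapiens) for antiproliferative activity, read by MTT assay, with a stated time of 24 h (a higher number here means a weaker inhibitor, a lower number a stronger inhibitor), a limit of the assay.
Compound 2 `COc1nc(Cl)nc(C)c1CCF` has "not determined" (no result reported) in this assay.
Compound 3 `COc1nc(Cl)nc(C)c1CCOC(C)=O` gives > 100000 nM in this assay, again a limit.

Compound 1 therefore stands only at a limit, as does compound 3, and the step from compound 1 to compound 3 is a step that the two limits leave unreadable from compound 1 to compound 3 because of the limit of > 100000 nM in this assay, at which 2 of the 3 values shown sit. Compound 4 `Cc1nc(Cl)nc(Cl)c1CCCl` differs from compound 1 by chloro in place of acetoxy on a saturated chain carbon, two bonds along the chain from an aromatic carbon. Within the data shown here, no measured step bears on this change, and both values shown sit at the limit, so no direction beyond the scatter can be read. The step from compound 1 to compound 4 is estimated as an at least 1.2-fold lower number from compound 1 to compound 4 (0.09 log units; that floor lies within the scatter), with compound 4 expected near 80000 nM, within 10000 nM to 300000 nM.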

Compound 4, half-maximal inhibitory concentration: 5000 nM
Beside the measured number, compound 4's estimate is 16-fold (1.20 log units) above it; measured number outside the range, below it.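

Chloro in place of acetoxy on a saturated chain carbon, two bonds along the chain from an aromatic carbon, gives an at least 20-fold lower number from compound 1 to compound 4 (1.30 log units; beyond the scatter) in this assay. This is the first readable change among these compounds, and it shows that the number responds to what this chain carries. Going by these compounds, its full size stays open because compound 1 rests on a limit: the limit of > 100000 nM in this assay, at which 2 of the 4 values shown sit.

The compounds shown do not tell how a hydroxyl, an amine or a bromo group would read at this place. They also leave open whether methoxy in place of chloro on the aromatic carbon would alter the number of compound 4.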